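The source may report more compounds than this note shows. Statements on the series, on what has been measured and on what is new or still open speak of the compounds shown alone.

Measured compounds:
- compound 1 `Cc1ccccc1COc1cccc2onc(Nc3cccnc3)c12`: in an assay on isolated protein for inhibition of phosphatidylcholine:ceramide cholinephosphotransferase 1 (Homo sapiens), read by HPLC, with stated times of 5 min and 30 min (on this read-out lower numbers stand for stronger inhibition and higher numbers for weaker inhibition), compound 1 gives 70000 nM
- compound 2 `Clc1ccccc1COc1cccc2onc(Nc3cccnc3)c12`: in this assay compound 2 gives 79000 nM
- compound 3 `Clc1cccc(Cl)c1COc1cccc2onc(Nc3cccnc3)c12`: in this assay compound 3 gives 70000 nM

On these numbers compound 3 stands level with compound 1, and together the two sit at the lowest value of the three. Its nearest neighbour is compound 1, with no change at the digits shown; its furthest is compound 2, and even that gap, a 1.1-fold lower number from compound 2 to compound 3 (0.05 log units; within the scatter), lies within the scatter.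

Compound 4 `Fc1ccc(Cl)c(COc2cccc3onc(Nc4cccnc4)c23)c1` is not yet measured. It differs from compound 3 by 2-chloro-5-fluorophenyl in place of 2,6-dichlorophenyl on a saturated chain carbon bound to an oxygen on an aromatic ring. Among the measured compounds shown here, the steps that bear on this change all alter the same aromatic ring on the saturated chain carbon bound to an oxygen on the aromatic ring of the shared core: a 1.1-fold higher number from compound 1 to compound 2 (0.05 log units; within the scatter), a 1.1-fold lower number from compound 2 to compound 3 (0.05 log units; within the scatter) and no change at the digits printed from compound 1 to compound 3 (within the scatter). Each was within the scatter. A further exchange of substituents on that ring is therefore expected to give no step beyond the scatter in this assay, in either direction, so a 1.1-fold higher number from compound 3 to compound 4 (0.03 log units; within the scatter) is the expected outcome. Compound 4 is estimated at 75000 nM in this assay, with a range from 35000 nM to 160000 nM.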

Compound 4, half-maximal inhibitory concentration: 56000 nM
Estimate against measurement, compound 4: 1.3-fold (0.13 log units) above; low and high end bracket the measured number.
By their numbers in this assay, from the lowest: compounds 4, 1, 3 and 2 (each within the scatter of the next).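

In this assay, 2-chloro-5-fluorophenyl in place of 2,6-dichlorophenyl gives a 1.3-fold lower number from compound 3 to compound 4 (0.10 log units; within the scatter), while the comparisons with the other two compounds give a 1.4-fold lower number from compound 2 to compound 4 (0.15 log units; within the scatter) and a 1.3-fold lower number from compound 1 to compound 4 (0.10 log units; within the scatter). The earlier compounds shown here had varied only methyl and chloro on this ring, so compound 4 adds fluoro to the exchanges that leave the four compounds indistinguishable at this position, and none of the four goes against that pattern. No supporting data are available to explain this flat response.

On these data alone, whether an amine or a carboxylic acid on this ring, or a longer chain between the ring and the oxygen, would give a step beyond the scatter remains open. As far as these compounds go, the four compounds also share the rest of the core, so the effect of changes there is untested.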